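The compounds below may be only part of what the source reports. "The series", "measured", "known", "first", "only" and "open" are said of these compounds alone.

Compound 1 `COc1ccccc1-c1cnc(N)nc1-c1ccccc1`: 20%
Compound 2 `Nc1ncc(-c2ccc(C(F)(F)F)cc2)c(-c2ccccc2)n1`: 51%
Compound 3 `CCCC(=O)Nc1ncc(-c2cccc(Cl)c2)c(-c2ccccc2)n1`: > 80%

Of the compounds shown here, three built on a shared core have been tested in an assay on CHO cells for displacement of a labelled ligand from adenosine receptor A1 (Homo sapiens), read by scintillation counting, with a stated time of 1 h, tested at 1 uM; on this read-out lower numbers stand for less inhibition and higher numbers for more inhibition at the one concentration tested (going by the name of the read-out). Compound 1 gives 20% in this assay, and compound 2 gives 51%. Compound 3 gives > 80%, which is a limit of the assay rather than a number. Compound 3 therefore stands at the edge of the numbers shown, the point marked by the limit of > 80% in this assay, at which 1 of the 3 values shown sits, and only a range is known for it. Within the data shown here, no two of the measured compounds differ in just one place, so no single measured step is available to lean on.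

Compound 4 `CC(C)CCNc1ncc(-c2cccc(Cl)c2)c(-c2ccccc2)n1` has not yet been measured. It differs from compound 3 in one place: isopentyl in place of propylcarbonyl on a nitrogen on an aromatic ring. Among the measured compounds shown here, with no measured pair showing this kind of change, the expectation rests on the structural change alone; a downward step from compound 3 to compound 4 of about a number at least 20 percentage points lower from compound 3 to compound 4 (beyond the scatter) is expected, larger than the usual scatter. Compound 4 is estimated to give 60% in this assay, with a likely range from 30% to 85%.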

Compound 4, a percentage reported as inhibition, at one concentration (the size of the read-out at that concentration, not a potency): 39%
Compound 4: middle estimate off by 21 percentage points, on the high side; measured number inside the range.
By their numbers in this assay, from the lowest: compound 1; then compound 4; then compound 2. At a limit, above all of these: compound 3.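

On a nitrogen on an aromatic ring, with the rest of the molecule unchanged, isopentyl in place of propylcarbonyl gives a number at least 41 percentage points lower from compound 3 to compound 4 (beyond the scatter) in this assay. Among these compounds, this is the first pair differing in one place, and it shows that the group on this nitrogen matters: the two groups have the same count of heavy atoms and no ring, so the step does not come with a change in that count, and they differ in the carbonyl and in the shape of the chain. The step is open-ended, since compound 3 gives a limit and not a number: the limit of > 80% in this assay, at which 1 of the 4 values shown sits.

This single pair cannot tell whether the loss of the carbonyl or the branched chain end goes with the step. As far as these compounds go, a straight pentyl chain on the same nitrogen would help to separate the two, and how it would compare remains open.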